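Swapping a Bulky Dialkoxy Amine Substituent for Butylamino

This account rests on a few compounds, and the source may have more. Where it says the series, first, only, none or still open, it means among the compounds named here.

Measured compounds:
compound 1 `CCCCN(CC)c1nc(C)nc2c1nnn2-c1c(C)cc(C)cc1C` gives 27.5 nM
compound 2 `CCCCN(CC)c1nc(C)nc2c1nnn2-c1ccc(C(C)C)cc1Br` gives 7.5 nM
compound 3 `CCN(c1nc(C)nc2c1nnn2-c1ccc(C(C)C)cc1Br)C(COC)COC` gives 123 nM

All three numbers come from an in vitro assay on 293-EBNA cells for binding affinity to corticotropin-releasing factor receptor 1 (Homo sapiens); a higher number here means a weaker inhibitor, a lower number a stronger inhibitor. Compound 3 stands at the high end of this small set: it gives the highest number of the three, compound 1 sitting closer to it and compound 2 furthest away. Among the compounds with values here, the only step that can be traced to a single change is a 16-fold higher number from compound 2 to compound 3 (1.21 log units; beyond the scatter), where 2-methoxy-1-(methoxymethyl)ethyl took the place of butyl on a nitrogen on an aromatic ring and the number rose sharply.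

Compound 4 `CCCCNc1nc(C)nc2c1nnn2-c1ccc(C(C)C)cc1Br` has not yet been measured in this assay. It differs from compound 3 by a group of 5 heavy atoms (4 carbon, 1 nitrogen; no ring) in place of a group of 10 heavy atoms (7 carbon, 1 nitrogen, 2 oxygen; no ring), on an aromatic carbon. Within the data shown here, this change runs opposite to the one that weakened compound 2 into compound 3, since butyl returns to that nitrogen, though compound 4 carries butylamino and compound 2 a differently substituted nitrogen, so no measured step matches it exactly. Given the large rise from compound 2 to compound 3, the number is expected to fall again for compound 4, by a 4.1-fold lower number from compound 3 to compound 4 (0.61 log units; beyond the scatter), though probably not all the way back to the number of compound 2. The estimate for compound 4 in this assay is 30 nM, within a range from 8 nM to 120 nM.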

Compound 4, inhibition constant: 69.6 nM
Beside the measured number, compound 4's estimate is 2.3-fold (0.37 log units) below it; measured number inside the range.
By their numbers in this assay, from the lowest: compound 2; then compound 1; then compounds 4 and 3 (each within the scatter of the next).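

In this assay, putting butylamino on the aromatic carbon in place of the larger group with two oxygens gives a 1.8-fold lower number from compound 3 to compound 4 (0.25 log units; within the scatter) and so leaves the two compounds indistinguishable, although the group that enters has fewer heavy atoms and brings a hydrogen-bond donor. The step that does stand out is a 9.3-fold higher number from compound 2 to compound 4 (0.97 log units; beyond the scatter) with hydrogen in place of ethyl on the nitrogen, which shows that the ethyl counts as well as the butyl. Among compounds 2, 3 and 4, only compound 2 carries both butyl and ethyl on that nitrogen, and changing either one raises the number beyond the scatter, to values for compound 3 and compound 4 that cannot be told apart.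

No measurement shown here explains why this nitrogen responds in this way. The compounds shown leave open whether methyl or propyl in place of the ethyl would hold the low number of compound 2, and whether a longer chain in place of the butyl would do the same.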